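From Methoxycarbonyl to Ethoxycarbonyl in a Growth Assay

A few compounds are considered here, and "the series" means these few. Any claim that something is new, unique, unknown or untested is made for them only; others in the source may bear on it.

In a functional assay on Hs 683 cells (Homo sapiens) for inhibition, read by MTT assay, with a stated time of 72 h (a higher number here means a weaker inhibitor of growth, a lower number a stronger inhibitor of growth), compound 1 `CC1(C)CCC[C@]2(C)[C@@H](C=O)C(C=O)=CC[C@@H]12` gives 95000 nM. Among the measured compounds shown here, compound 2 `COC(=O)/C=C/C1=CC[C@H]2C(C)(C)CCC[C@]2(C)[C@H]1C=O`, which carries 2-(methoxycarbonyl)ethenyl in place of formyl on a double-bonded ring carbon, gives 24000 nM, the lower of the two numbers measured so far.

Compound 3 `CCOC(=O)/C=C/C1=CC[C@H]2C(C)(C)CCC[C@]2(C)[C@H]1C=O` has not yet been measured in this assay. It differs from compound 2 by methyl in place of hydrogen on a saturated chain carbon bound to an oxygen next to a carbonyl group, so that methoxycarbonyl becomes ethoxycarbonyl.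

For the measured compounds named here, only one measured step bears on this change, and only indirectly: a 4.0-fold lower number from compound 1 to compound 2 (0.60 log units; beyond the scatter). That modest step exchanged a whole group, whereas the new change adds a single methyl to the end of that group. Going by the values given here, no measured pair shows a change within the methoxycarbonyl group itself, so the size of such a change remains unknown. No shift beyond the usual scatter is therefore expected, and the estimated step is a 1.1-fold lower number from compound 2 to compound 3 (0.04 log units; within the scatter). The expected value for compound 3 is 22000 nM, with an estimated range of 10000 nM to 50000 nM.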

Compound 3, concentration for 50% growth inhibition: 29000 nM
Compound 3: the middle estimate sits 1.3-fold (0.12 log units) below what was measured; the measured number falls inside the stated range.
By their numbers in this assay, from the lowest: compounds 2 and 3 (each within the scatter of the next); then compound 1.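

In this assay, the change from methoxycarbonyl to ethoxycarbonyl gives a 1.2-fold higher number from compound 2 to compound 3 (0.08 log units; within the scatter), so a methyl added on a saturated chain carbon bound to an oxygen next to a carbonyl group causes no shift beyond the scatter. The step away from the formyl group also survives this change: the ethoxycarbonyl form gives a 3.3-fold lower number from compound 1 to compound 3 (0.52 log units; beyond the scatter), which shows that the lower number seen earlier is not confined to the methoxycarbonyl form, with compound 2 and compound 3 standing together apart from compound 1. Nothing at hand explains why the ester's end can change in this way with so little effect on the number.

As far as these compounds go, whether this tolerance extends beyond ethyl, to a longer chain or a benzyl group, remains open, as does whether a carboxylic acid or an amide in place of the ester would stay level with compound 2 and compound 3. All of these numbers also come from a single cell line, so how the compounds would rank in other cells cannot be said.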